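The compounds below may be only part of what the source reports. "The series", "measured", "known", "first", "only" and "open" are said of these compounds alone.

Compounds measured in a functional assay on PC-3 cells (Homo sapiens) for cytotoxicity, read by MTT assay, with a stated time of 72 h; a lower number here means a stronger inhibitor, a higher number a weaker inhibitor:

Compound 1, `Nc1ccc(Nc2nc3ccccc3nc2S(=O)(=O)c2ccccc2)cc1`, gives 5830 nM.
Compound 2, `Nc1cccc(Nc2nc3ccccc3nc2S(=O)(=O)c2ccccc2)c1`, gives 2150 nM.
Compound 3, `Cc1ccc(S(=O)(=O)c2nc3ccccc3nc2Nc2ccc(N)cc2)cc1`, gives 5000 nM.

Compound 1 and compound 2 differ by one change, (3-aminophenyl in place of 4-aminophenyl on a nitrogen on an aromatic ring), and the step is a 2.7-fold lower number from compound 1 to compound 2 (0.43 log units; beyond the scatter). Compound 3 carries a second change against compound 1, (methyl in place of hydrogen on an aromatic carbon), which brings a 1.2-fold lower number from compound 1 to compound 3 (0.07 log units; within the scatter). The unmeasured compound 4, `Cc1ccc(S(=O)(=O)c2nc3ccccc3nc2Nc2cccc(N)c2)cc1`, differs from compound 3 by 3-aminophenyl in place of 4-aminophenyl on a nitrogen on an aromatic ring; the place of this change is the same as in the move from compound 1 to compound 2, so it is the same change applied to the core of compound 3.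

For compound 4 in this assay a step of about a 2.4-fold lower number from compound 3 to compound 4 (0.38 log units; beyond the scatter) is expected, resting on the earlier pair because a 2.7-fold lower number from compound 1 to compound 2 (0.43 log units; beyond the scatter) was seen there. The estimate for compound 4 is therefore 2100 nM, within a range from 1000 nM to 4500 nM.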

Compound 4, half-maximal inhibitory concentration: 2000 nM
Compound 4: middle estimate off by 1.1-fold (0.02 log units), on the high side; the range from low to high includes it.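

In this assay, among the compounds shown here, 3-aminophenyl in place of 4-aminophenyl brought a 2.5-fold lower number from compound 3 to compound 4 (0.40 log units; beyond the scatter), so this change carried over from one core to the other: the same change on two cores in this assay, a 2.7-fold lower number (0.43 log units; beyond the scatter) from compound 1 to compound 2 and a 2.5-fold lower number (0.40 log units; beyond the scatter) from compound 3 to compound 4, 1.1-fold (0.04 log units) apart, within the scatter of two such steps Methyl in place of hydrogen on an aromatic carbon brought a 1.1-fold lower number from compound 2 to compound 4 (0.03 log units; within the scatter), and it made as little difference here as on the earlier core: the same change on two cores in this assay, a 1.2-fold lower number (0.07 log units; within the scatter) from compound 1 to compound 3 and a 1.1-fold lower number (0.03 log units; within the scatter) from compound 2 to compound 4, 1.1-fold (0.04 log units) apart, within the scatter of two such steps This shows only that the two changes behaved independently across these four compounds; it does not show that the step would hold on a core differing by more than one methyl, nor why the steps take the sizes they do.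

The compounds shown leave open whether the same step would appear if the methyl gave way to a chlorine or a methoxy group. They also leave open what would happen if a carboxylic acid took the place of the amine.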